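Chalcone Amides Carrying Piperazine: A Predicted Fourth Analogue

A few compounds are considered here, and "the series" means these few. Any claim that something is new, unique, unknown or untested is made for them only; others in the source may bear on it.

Four compounds share a chalcone core linked through an amide to a phenylpiperazine. Compound 1 `CCCCCCCCn1cc(/C=C/C(=O)c2ccc(NC(=O)CN3CCN(c4ccccc4)CC3)cc2)nn1` gives 41400 nM in a functional assay on SK-N-SH cells (Homo sapiens) for inhibition, read by MTT assay; a higher number here means a weaker inhibitor, a lower number a stronger inhibitor. Compound 2 `O=C(CN1CCN(c2ccccc2)CC1)Nc1ccc(C(=O)/C=C/c2cn(Cc3ccc(Br)cc3)nn2)cc1` gives 72400 nM in this assay, and the change 4-bromophenyl in place of heptyl on a saturated chain carbon bound to an aromatic nitrogen produced a 1.7-fold higher number from compound 1 to compound 2 (0.24 log units; within the scatter). Compound 3 `CCCCCCCCn1cc(/C=C/C(=O)c2ccc(NC(=O)CN3CCN(c4ccc([N+](=O)[O-])cc4)CC3)cc2)nn1` gives 51400 nM in this assay; it differs from compound 1 by nitro in place of hydrogen on an aromatic carbon, a step of a 1.2-fold higher number from compound 1 to compound 3 (0.09 log units; within the scatter). All three numbers lie within the usual scatter of one another, so no ordering among them is claimed.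

Compound 4 `O=C(CN1CCN(c2ccc([N+](=O)[O-])cc2)CC1)Nc1ccc(C(=O)/C=C/c2cn(Cc3ccc(Br)cc3)nn2)cc1` has not yet been measured in this assay. Within the data shown here, its relation to compound 3 is 4-bromophenyl in place of heptyl on a saturated chain carbon bound to an aromatic nitrogen, which is the same change as the one made between compound 1 and compound 2, placed on the same saturated chain carbon bound to an aromatic nitrogen. The two cores differ by nitro in place of hydrogen on an aromatic carbon, which on its own moved the value only within the scatter.

Since the earlier instance of this change gave a 1.7-fold higher number from compound 1 to compound 2 (0.24 log units; within the scatter), and the nitro substitution in compound 3 gave a 1.2-fold higher number from compound 1 to compound 3 (0.09 log units; within the scatter), the step for compound 4 is expected to be a 1.7-fold higher number from compound 3 to compound 4 (0.23 log units; within the scatter). Compound 4 is therefore estimated at 87000 nM in this assay, with an expected range from 40000 nM to 190000 nM.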

Compound 4, half-maximal inhibitory concentration: 26500 nM
The estimate for compound 4 lay 3.3-fold (0.52 log units) above the measured number; the whole stated range lies above it.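

In this assay, putting 4-bromophenyl in place of heptyl on a saturated chain carbon bound to an aromatic nitrogen gave a 1.9-fold lower number from compound 3 to compound 4 (0.29 log units; within the scatter) on the nitro-bearing core, and this step differs from the earlier one on the core of compound 1: the same change on two cores in this assay, a 1.7-fold higher number (0.24 log units; within the scatter) from compound 1 to compound 2 and a 1.9-fold lower number (0.29 log units; within the scatter) from compound 3 to compound 4, 3.4-fold (0.53 log units) apart, beyond the scatter of two such steps. Adding the nitro group to the core of compound 2 gave a 2.7-fold lower number from compound 2 to compound 4 (0.44 log units; beyond the scatter), the one new step beyond the scatter, and this too differs from the same change on the other core: the same change on two cores in this assay, a 1.2-fold higher number (0.09 log units; within the scatter) from compound 1 to compound 3 and a 2.7-fold lower number (0.44 log units; beyond the scatter) from compound 2 to compound 4, 3.4-fold (0.53 log units) apart, beyond the scatter of two such steps. These four compounds therefore show that neither change carried over as a fixed step from one core to the other, but they form a single set in which compound 4 enters both comparisons, so they do not show how general this is or what lies behind it.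

The compounds shown leave open whether the same mismatch appears when an amine or a carboxylic acid stands in place of the nitro group on the aromatic carbon. They also leave open whether it persists with a longer chain or an unsubstituted benzyl in place of octyl or 4-bromobenzyl.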